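Chloro in Place of Methoxy on a Piperidinyl Thiazolidinone

A few compounds are considered here, and "the series" means these few. Any claim that something is new, unique, unknown or untested is made for them only; others in the source may bear on it.

Compound 1 `COc1ccccc1C1SCC(=O)N1CCN1CCCCC1`: 100%
Compound 2 `COc1cccc(C2SCC(=O)N2CCN2CCCCC2)c1`: 90%

Of the compounds shown here, two have been read in an ADME assay on Vero cells (Chlorocebus sabaeus) for cytotoxicity, read by neutral red uptake, tested at 49 ug/mL; on this read-out higher numbers stand for a weaker effect at the one concentration tested and lower numbers for a stronger effect. Compound 1 gives 100% there, which is the higher of the two numbers, while compound 2 gives 90%; the gap between them is stated to lie within the scatter, so the two are not told apart by this assay. Within the data shown here, no step between measured compounds that differ in one place is available, so there is nothing yet to show how a single change on the aromatic ring moves the read-out.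

The next compound, compound 3 `O=C1CSC(c2ccccc2Cl)N1CCN1CCCCC1`, differs from compound 1 in one place: chloro in place of methoxy on an aromatic carbon. Both measured compounds show a weak effect at the tested concentration, and nothing in the data points to a change of that picture. For compound 3 the step is expected to be small or none beyond the scatter, a drop of a number 10 percentage points lower from compound 1 to compound 3 (within the scatter) in this assay. Compound 3 is therefore estimated at 90%, with a range from 70% to 100%.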

Compound 3, a percentage reported as activity, at one concentration (the size of the read-out at that concentration, not a potency): 100%
Compound 3: middle estimate off by 10 percentage points, on the low side, within the range that was stated.
By their numbers in this assay, from the lowest: compounds 2, 1 and 3 (each within the scatter of the next).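

In this assay, among these compounds, chloro in place of methoxy on an aromatic carbon, ortho to a large group, gives no change at the digits printed from compound 1 to compound 3 (within the scatter) and so provides the first comparison of compounds that differ in one place. At this position, a group of two heavy atoms with one hydrogen-bond acceptor gives way to a single chlorine with no acceptor, and the read-out does not tell the two compounds apart. The finding is limited to this one exchange at this one place and this one tested concentration, and no measurement shown offers an explanation for it.

The compounds shown leave open whether a group of another kind at this position, such as an amine, a carboxylic acid or a longer alkyl chain, would also leave the read-out undisturbed or would bring out a stronger effect. They also leave open whether chloro would read the same at the ring position that carries the methoxy in compound 2, and whether changes elsewhere on the shared core would matter more than this one.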